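The source may report more compounds than this note shows. Statements on the series, on what has been measured and on what is new or still open speak of the compounds shown alone.

In an ADME assay on microsomes from liver (Mus musculus) for metabolic stability, read by LC-MS, with NADPH named in the record, with a stated time of 60 min, tested at 1 uM, in the absence of a further agent (on this read-out higher numbers stand for a more stable compound and lower numbers for a less stable compound), three compounds have been examined so far, and each returned only a limit. Compound 1 `CC(=O)N[C@@H]1CCN(c2cc(C)nn3c(-c4cccc(S(=O)(=O)N(C)C)c4)c(C)nc23)C1` gives > 95%, a limit of the assay rather than a number. Compound 2 `CC(=O)N[C@@H]1CCN(c2cc(C)nn3c(-c4cccs4)c(C)nc23)C1` gives > 95%, again a limit. Compound 3 `COc1ccc(-c2c(C)nc3c(N4CC[C@@H](NC(=O)c5ccccc5)C4)cc(C)nn23)cc1OC` gives > 95%, also a limit. Compound 3 thus stands where the whole set stands (the limit of > 95% in this assay, at which 3 of the 3 values shown sit), with no number to separate it from the others. Compound 4 `COc1ccc(-c2c(C)nc3c(N4CC[C@@H](NS(=O)(=O)C5CC5)C4)cc(C)nn23)cc1OC` has not yet been measured; it differs from compound 3 in one place (cyclopropylsulfonyl in place of benzoyl on an amine nitrogen). Going by the values given here, no measured pair shows what such a change does here. Compound 4 is expected to remain at the limit, so the expected step of a number no higher from compound 3 to compound 4 (the limit leaves the size open) is none beyond the scatter. The estimate for compound 4 is 95%, between 85% and 99%.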

Compound 4, percent of the compound remaining: > 95%
Compound 4: a limit, no number (the forecaster's own chance of this, stated with the estimate: 70%); the middle value sits exactly at the limit.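

No step from compound 3 to compound 4 can be read, since both compounds return only a limit: the limit of > 95% in this assay, at which 4 of the 4 values shown sit.

The compounds shown leave open what cyclopropylsulfonyl in place of benzoyl does in this assay, and how any of these compounds ranks against the others.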